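Swapping the Aryl Group on the Amine Nitrogen

This account rests on a few compounds, and the source may have more. Where it says the series, first, only, none or still open, it means among the compounds named here.

Compound 1 `O=C1C(Nc2ccc(I)cc2)=CC(=O)c2c1nc1n2[C@H]2OC[C@@H](O)[C@H]2OC1` has been tested in a functional assay on MCF7 cells (Homo sapiens) for inhibition, read by sulforhodamine B assay (a lower number here means a stronger inhibitor, a higher number a weaker inhibitor), where compound 1 gives 3890 nM. For the measured compounds named here, only one other number has been measured in this assay: compound 2 `Cc1ccc(NC2=CC(=O)c3nc4n(c3C2=O)[C@H]2OC[C@@H](O)[C@H]2OC4)cc1C` gives 2080 nM, and the gap between these two lies within the usual scatter. Compound 3 `CCCN(CCC)C1=CC(=O)c2nc3n(c2C1=O)[C@H]1OC[C@@H](O)[C@H]1OC3` gives > 16000 nM, which is a limit of the assay rather than a number, as recorded in the limit of > 16000 nM in this assay, at which 1 of the 3 values shown sits. Going by the values given here, the single step between measured neighbours, an at least 7.6-fold higher number from compound 2 to compound 3 (0.88 log units; beyond the scatter), replaces the (3,4-dimethylphenyl)amino group with a dipropylamino group.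

Compound 4 `CCOc1ccccc1NC1=CC(=O)c2c(nc3n2[C@H]2OC[C@@H](O)[C@H]2OC3)C1=O` differs from compound 1 by 2-ethoxyphenyl in place of 4-iodophenyl on an amine nitrogen. The step from compound 2 to compound 3 changes the kind of group on the amine nitrogen altogether, so it does not bear directly on this change. What comes closer is the pair of compound 1 and compound 2, which carry a 4-iodophenyl and a 3,4-dimethylphenyl on that nitrogen and yet give values within the scatter of each other. In this assay, the step is therefore expected to be a 1.3-fold lower number from compound 1 to compound 4 (0.11 log units; within the scatter), not clearly beyond the scatter and in no preferred direction. Compound 4 is estimated at 3000 nM, with a range from 1000 nM to 9000 nM.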

Compound 4, half-maximal inhibitory concentration: > 4000 nM
Compound 4 gave a limit, no number (the forecaster's own chance of this, stated with the estimate: 10%); middle value at least 1.3-fold (0.12 log units) from the limit.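

In this assay compound 4 gives > 4000 nM, which is a limit of the assay and not a number. Read as a step, the swap gives an at least 1.0-fold higher number from compound 1 to compound 4 (0.01 log units; that floor lies within the scatter), so 2-ethoxyphenyl on this amine nitrogen brings no lower number than 4-iodophenyl, while the true size of the change stays unknown. Compound 1 and compound 2 both gave measured numbers with an aryl group on this nitrogen, but compound 4 shows that carrying such a group does not ensure a measured number in this series: the limit of > 4000 nM in this assay, at which 1 of the 4 values shown sits.

The compounds shown leave open how far beyond its limit the true value of compound 4 lies, and so whether replacing 4-iodophenyl with 2-ethoxyphenyl makes any real difference. They also leave open what an unsubstituted phenyl or a benzyl group on this amine nitrogen would give.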